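From sec-butyl to 1-cyclohexylethyl in a rat inhibition assay

The source may hold more compounds than are shown below. What is called first, only, known or untested is meant among the compounds shown, and "the series" means these compounds.

Three compounds have values in a functional assay for inhibition, with Rattus norvegicus as the target; a higher number here means a weaker inhibitor, a lower number a stronger inhibitor. Compound 1 (`CC(/N=c1\c(O)c(O)\c1=N/c1cccnc1O)C(C)(C)C`) gives > 30000 nM as a limit of the assay and not a number. Compound 2 (`CC(C)(C)/N=c1\c(O)c(O)\c1=N/c1ccc2ncccc2c1`) likewise gives > 30000 nM as a limit and not a number. For the measured compounds named here, compound 3 (`CCC(C)/N=c1\c(O)c(O)\c1=N/c1ccc(C#N)cc1`) gives 2100 nM as the only true number among the three, so it is the single measured reference point.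

Compound 4 (`C[C@H](/N=c1\c(O)c(O)\c1=N/c1ccc(C#N)cc1)C1CCCCC1`) has not yet been measured. It keeps the core of compound 3 but carries 1-cyclohexylethyl in place of sec-butyl on a double-bonded nitrogen. Going by the values given here, no pair of measured compounds differs at this place alone, so the size of the change has no direct precedent.

With compound 3 at 2100 nM as the starting point, a moderate move toward a lower number in this assay is expected, beyond the usual scatter, though this is a judgement with wide uncertainty. The estimated change is a step of a 3.5-fold lower number from compound 3 to compound 4 (0.54 log units; beyond the scatter) in this reading. For compound 4 the expected value is 600 nM with an estimated range from 100 nM to 4000 nM in the measurement to come.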

Compound 4, half-maximal inhibitory concentration: > 30000 nM
Compound 4: only a limit was reported; the forecaster's own chance of this, stated with the estimate: 8%; middle value at least 50-fold (1.69 log units) from the limit.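

In this assay, for the compounds shown here, putting 1-cyclohexylethyl in place of sec-butyl on a double-bonded nitrogen gives an at least 14-fold higher number from compound 3 to compound 4 (1.15 log units; beyond the scatter) and is the first step at this place that can be read. Going by these compounds alone, it shows that this place is not indifferent to which carbon-only group it carries, something the earlier compounds could not show, as none of them formed a pair differing at this place alone. Compound 4 gives > 30000 nM which is a limit of the assay and not a number, so the step marks only a floor and its true size stays unknown: the limit of > 30000 nM in this assay, at which 3 of the 4 values shown sit.

The compounds shown leave open whether the loss follows from the six-membered ring, from the larger number of carbons, or from the defined stereocentre, and the opposite stereoisomer of compound 4 would bear on the last of these. They also leave open how a smaller ring such as cyclopropyl, a straight butyl chain, or a cyclohexyl ring carrying a hydroxyl group or an amine would read at this place on the core of compound 3.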